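Pyridine substituent swaps and passive permeability

The source may hold more compounds than are shown below. What is called first, only, known or untested is meant among the compounds shown, and "the series" means these compounds.

Measured compounds:
compound 1, `Cc1ccnc(Oc2ccc3nc(COc4cccc(C(=O)O)c4)n(C)c3c2)c1`: 3.5 10^-6 cm/s
compound 2, `Cn1c(COc2cccc(C(=O)O)c2)nc2ccc(Oc3ncccc3F)cc21`: 3.9 10^-6 cm/s
compound 3, `Cc1ccc(Oc2ccc3nc(COc4cccc(C(=O)O)c4)n(C)c3c2)nc1C`: 7.7 10^-6 cm/s

The three compounds share one core and differ only in the pyridine ring attached through an oxygen on an aromatic ring. All values come from an ADME assay for permeability, using PAMPA, with a stated time of 4 h; a lower number here means that the compound crosses the layer more slowly, a higher number that the compound crosses the layer faster. Compound 3 stands apart from compound 1, with a 2.2-fold higher number from compound 1 to compound 3 (0.34 log units; beyond the scatter), whereas the gap to compound 2, a 2.0-fold higher number from compound 2 to compound 3 (0.30 log units; within the scatter), is within the scatter, so compound 3 and compound 2 cannot be told apart on these numbers. Compound 1 and compound 2 are also close, a 1.1-fold higher number from compound 1 to compound 2 (0.05 log units; within the scatter).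

Compound 4, `Cc1cc(Cl)cnc1Oc1ccc2nc(COc3cccc(C(=O)O)c3)n(C)c2c1`, has not yet been measured. The change from compound 3 is 5-chloro-3-methylpyridin-2-yl in place of 5,6-dimethylpyridin-2-yl on an oxygen on an aromatic ring. Every measured step is of the same kind, an exchange of one substitution pattern on that pyridine ring for another, and the largest of them reached only a modest size. The expected step, a 1.2-fold lower number from compound 3 to compound 4 (0.07 log units; within the scatter), is therefore small, with no confident direction and nothing clearly beyond the scatter. Compound 4 is expected to give 6.5 10^-6 cm/s, within a range from 3.5 10^-6 cm/s to 12 10^-6 cm/s in this assay .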

Compound 4, apparent permeability: 13.7 10^-6 cm/s
For compound 4 the middle estimate is 2.1-fold (0.32 log units) below the measured one; the whole stated range lies below it.
By their numbers in this assay, from the lowest: compounds 1, 2, 3 and 4 (each within the scatter of the next, the first and the last beyond it).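

In this assay, putting the 5-chloro-3-methylpyridin-2-yl group on this oxygen gives a 3.5-fold higher number from compound 2 to compound 4 (0.55 log units; beyond the scatter) and a 3.9-fold higher number from compound 1 to compound 4 (0.59 log units; beyond the scatter), the widest steps seen so far at this position. Against the 5,6-dimethylpyridin-2-yl group, the same group gives a 1.8-fold higher number from compound 3 to compound 4 (0.25 log units; within the scatter), so these two substituted pyridines cannot be told apart here, even though a chlorine enters and the pattern of substituents on the ring changes. The data shown offer no measurement that explains the size of any of these steps.

Compound 4 differs from compound 3 in both the chlorine and the placement of its methyl group, so the compounds shown cannot separate what each of these changes contributes. Also open, on these data alone, is how this assay would read with a methoxy group, a nitrile or an amine on the pyridine, or with a plain phenyl ring in place of the pyridine.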